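Swapping the Aryl Group on an Amide-Type Nitrogen

The source may hold more compounds than are shown below. What is called first, only, known or untested is meant among the compounds shown, and "the series" means these compounds.

Of the compounds shown here, three sharing one core have been tested in a functional assay on T-24 cells (Homo sapiens) for antiproliferative activity, read by MTT assay, with a stated time of 48 h; on this read-out lower numbers stand for stronger inhibition and higher numbers for weaker inhibition. Compound 1 `Cc1ccc(NC(=O)Nc2cccc(CNc3nccnc3Cl)c2)cc1` gives 9820 nM in this assay. Compound 2 `O=C(Nc1cccc(CNc2nccnc2Cl)c1)Nc1ccccc1Cl` gives 6680 nM, and compound 3 `Cc1ccc(NC(=O)Nc2cccc(CNc3nccnc3Cl)c2)cc1Cl` gives 7390 nM. Compound 2 shows the lowest of the three numbers, but its distance to its nearest neighbour, compound 3, and to compound 1 lies within the scatter, so the three cannot be told apart on these data. The steps among them, a 1.5-fold lower number from compound 1 to compound 2 (0.17 log units; within the scatter), a 1.3-fold lower number from compound 1 to compound 3 (0.12 log units; within the scatter) and a 1.1-fold higher number from compound 2 to compound 3 (0.04 log units; within the scatter), each exchange the aryl group on the amide-type nitrogen, and each falls within the scatter.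

Compound 4 `Cc1ccc(NC(=O)Nc2cccc(CNc3nccnc3Cl)c2)c(C)c1` has not yet been measured. It differs from compound 2 in one place: 2,4-dimethylphenyl in place of 2-chlorophenyl on an amide-type nitrogen. The three measured steps bear directly on this change, since every one of them also swaps the aryl group on the amide-type nitrogen, and none of them moved the number beyond the scatter. Compound 4 is therefore expected to show no step beyond the scatter, a 1.1-fold higher number from compound 2 to compound 4 (0.05 log units; within the scatter). The estimate for compound 4 in this assay is 7500 nM, with a range from 3500 nM to 16000 nM.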

Compound 4, half-maximal inhibitory concentration: 9230 nM
For compound 4 the middle estimate is 1.2-fold (0.09 log units) below the measured one; the range from low to high includes it.
By their numbers in this assay, from the lowest: compounds 2, 3, 4 and 1 (each within the scatter of the next).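

In this assay the 2,4-dimethylphenyl group on the amide-type nitrogen stays within the scatter of all three aryl groups measured before it, with a 1.4-fold higher number from compound 2 to compound 4 (0.14 log units; within the scatter), a 1.2-fold higher number from compound 3 to compound 4 (0.10 log units; within the scatter) and a 1.1-fold lower number from compound 1 to compound 4 (0.03 log units; within the scatter). Among these compounds, compound 4 thus adds two readings that the earlier compounds did not give: a second methyl on an aromatic carbon of the aryl group of compound 1 leaves the number within the scatter, and so does the exchange of 2-chlorophenyl for an aryl group of carbon only that carries two methyl groups. The four compounds therefore cannot be told apart at this position, and nothing measured here explains why these aryl groups give such similar numbers.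

Methyl and chloro are the only groups shown on this aryl ring, so it remains open whether an amine, a carboxylic acid or a longer chain there would move the number beyond the scatter. All four compounds also share the same core, which leaves open how a change elsewhere in the molecule, such as replacing its chloro with an amine, would compare.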